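Amide-chain branching in the benzamide series

A few compounds are considered here, and "the series" means these few. Any claim that something is new, unique, unknown or untested is made for them only; others in the source may bear on it.

The series shares one core; compound 1 `COc1cc(N)c(Cl)cc1C(=O)NC1CCN(CC2CCN(CCCCN)CC2)CC1`, compound 2 `COc1cc(N)c(Cl)cc1C(=O)NC1CCN(CC2CCN(CC(C)CN)CC2)CC1` and compound 3 `COc1cc(N)c(Cl)cc1C(=O)NC1CCN(CC2CCN(C(=O)CCN)CC2)CC1` differ only in the group carried on the amine nitrogen of the outer ring. In an assay on striatum for inhibition of 5-hydroxytryptamine receptor 4 (Cavia porcellus), read by radioligand binding (a lower number here means a stronger inhibitor, a higher number a weaker inhibitor), compound 1 gives 6.47 nM, compound 2 gives 14.3 nM and compound 3 gives 9.5 nM. Compound 3 therefore stands second highest of the three numbers, but the steps of a 1.5-fold higher number from compound 1 to compound 3 (0.17 log units; within the scatter) and a 1.5-fold lower number from compound 2 to compound 3 (0.18 log units; within the scatter) both lie within the scatter, so the three sit close together in this assay.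

Compound 4 `COc1cc(N)c(Cl)cc1C(=O)NC1CCN(CC2CCN(C(=O)C(C)(C)N)CC2)CC1` carries the change (1-amino-1-methylethyl in place of 2-aminoethyl on a carbonyl carbon), that is, (2-aminoethyl)carbonyl to (1-amino-1-methylethyl)carbonyl. For the measured compounds named here, no measured step makes exactly this change. The nearest guide is a 2.2-fold higher number from compound 1 to compound 2 (0.34 log units; beyond the scatter), where branching of the chain on the ring nitrogen gave a modest, if real, shift; the step of a 1.5-fold higher number from compound 1 to compound 3 (0.17 log units; within the scatter) shows that a wider swap of the group on that nitrogen moved the number little. On that basis a modest rise of the number in this assay is expected for compound 4, of about a 1.9-fold higher number from compound 3 to compound 4 (0.28 log units; within the scatter). Compound 4 is thus estimated at 18 nM in this assay, with a range from 7 nM to 45 nM.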

Compound 4, half-maximal inhibitory concentration: 2.6 nM
Beside the measured number, compound 4's estimate is 6.9-fold (0.84 log units) above it; the whole stated range lies above it.
By their numbers in this assay, from the lowest: compound 4; then compounds 1, 3 and 2 (each within the scatter of the next, the first and the last beyond it).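

For the compounds shown here, on a carbonyl carbon, 1-amino-1-methylethyl in place of 2-aminoethyl gives a 3.7-fold lower number from compound 3 to compound 4 (0.56 log units; beyond the scatter) in this assay, the first step that lies beyond the scatter towards a lower number. The same group also separates the new amide from both saturated chains on the amine nitrogen, with a 5.5-fold lower number from compound 2 to compound 4 (0.74 log units; beyond the scatter) and a 2.5-fold lower number from compound 1 to compound 4 (0.40 log units; beyond the scatter), so compound 4 is the most potent of the four here, with its steps to all the others beyond the scatter. Branching therefore has no single direction across the listed compounds: the branched chain in the earlier pair went the other way, with a 2.2-fold higher number from compound 1 to compound 2 (0.34 log units; beyond the scatter), and so stands against any rule that branching lowers the number.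

No measurement in hand accounts for the lower number of compound 4. The compounds shown leave open whether both methyl groups are needed, which 1-aminoethyl on the same carbonyl carbon would test, and whether a ring such as 1-aminocyclopropyl or a tertiary amine such as 1-(dimethylamino)-1-methylethyl would hold the number at this level.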